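Dropping a Methoxy Group: From Compound 2 to Compound 3

A few compounds are considered here, and "the series" means these few. Any claim that something is new, unique, unknown or untested is made for them only; others in the source may bear on it.

The study concerns a small set of amide-linked compounds sharing one core. Compound 1 `COc1cc2c(Oc3ccc(NC(=O)c4cc(-c5ccccc5)ccn4)cc3F)ccnc2cc1OCCCN1CCN(C)CC1` carries a methylpiperazine at the end of its propoxy chain and a plain phenyl on the pyridine amide. In a functional assay on U-87MG ATCC cells (Homo sapiens) for cytotoxicity, read by MTT assay, with a stated time of 72 h (a higher number here means a weaker inhibitor, a lower number a stronger inhibitor), compound 1 gives 1010 nM. Compound 2 `COc1ccc(-c2ccnc(C(=O)Nc3ccc(Oc4ccnc5cc(OCCCN6CCCCC6)c(OC)cc45)c(F)c3)c2)cc1` differs from it in two places at once: a piperidine in place of the methylpiperazine, and a 4-methoxyphenyl in place of the phenyl. In this assay compound 2 gives "not determined" (no result reported), so compound 2 stands nowhere on the scale shown and no step from it to anything measured can be stated.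

Compound 3 `COc1cc2c(Oc3ccc(NC(=O)c4cc(-c5ccccc5)ccn4)cc3F)ccnc2cc1OCCCN1CCCCC1` is compound 2 with the change (hydrogen in place of methoxy on an aromatic carbon). Going by the values given here, since compound 2 has no value, the size and direction of this step in this assay cannot be read from the data; the only anchor is compound 1, which shares the phenyl of compound 3 and differs from it solely in the terminal amine. Compound 3 is therefore expected to land near 1000 nM, with a range of 300 nM to 3500 nM.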

Compound 3, half-maximal inhibitory concentration: 790 nM
The estimate for compound 3 lay 1.3-fold (0.10 log units) above the measured number, and the stated range covers the measured number.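

In this assay, going by these compounds alone, the result gives the first reading of the amine at the end of the propoxy chain: with the phenyl on the pyridine amide held constant, piperidin-1-yl in place of 4-methylpiperazin-1-yl gives a 1.3-fold lower number from compound 1 to compound 3 (0.11 log units; within the scatter) and the two compounds cannot be told apart in this assay. The position that carries the amine thus shows no response to this one exchange, which is all a single pair can show, while the step from compound 2 to compound 3, with hydrogen in place of methoxy, cannot be read, as compound 2 has no value. Nothing measured alongside these numbers offers an explanation for the result.

On these data alone, what a methoxy group on the phenyl does in this assay remains open, as does the effect of other groups at that carbon, para to a large group, such as fluorine, a hydroxyl or a nitrile. As far as these compounds go, it is equally open whether a different terminal amine, such as morpholine or dimethylamine, or a longer chain would leave the reading as it stands.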